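This account rests on a few compounds, and the source may have more. Where it says the series, first, only, none or still open, it means among the compounds named here.

Among the measured compounds shown here, compound 1 `Cc1n[nH]c2ccc(-c3nc4cnc(N5CCN(C)CC5)cn4c3Nc3ccc(Br)cc3)cc12` is the only member of this small series with a result in a functional assay on MV4-11 cells (Homo sapiens) for inhibition, with a stated time of 120 h (a higher number here means a weaker inhibitor, a lower number a stronger inhibitor), where compound 1 gives 2600 nM. For the measured compounds named here, compound 2 `Cc1n[nH]c2ccc(-c3nc4cnc(N5CCN(C)CC5)cn4c3Nc3ccccc3)cc12` shares the same core but carries a plain phenyl on the aniline nitrogen; in this assay compound 2 is recorded as "not determined" (no result reported), so there is no number on which compound 2 can be placed, and no step between measured compounds is available in this set. Compound 3 `Cc1cc(Br)ccc1Nc1c(-c2ccc3[nH]nc(C)c3c2)nc2cnc(N3CCN(C)CC3)cn12` differs from compound 2 in one place: 4-bromo-2-methylphenyl in place of phenyl on a nitrogen on an aromatic ring. Compound 3 thus carries the same bromine as compound 1 and, in addition, a methyl on the aromatic ring that sits on the nitrogen. Going by the values given here, with no measured pair to anchor the size or direction of this step, the expectation for compound 3 can rest only on compound 1, whose reading of 2600 nM is the one point of reference. On that basis compound 3 is expected to give about 2000 nM in this assay, with a range from 500 nM to 8000 nM reflecting the absence of any measured step.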

Compound 3, half-maximal inhibitory concentration: 10900 nM
Compound 3: middle estimate off by 5.5-fold (0.74 log units), on the low side; the whole stated range lies below it.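

Among the compounds shown here, with the bromine held in place, the methyl on the aromatic ring that sits on the nitrogen gives the first measured step in this set: in this assay there is a 4.2-fold higher number from compound 1 to compound 3 (0.62 log units; beyond the scatter) in this read-out. Within this pair, then, the added methyl goes with a weaker inhibitor, by more than the usual scatter, which the single reading for compound 1 could not show. The full change from phenyl to 4-bromo-2-methylphenyl cannot be read, as compound 2 has no number, and nothing shown bears on why the methyl step has this direction or size.

Going by these compounds, it remains open whether a fluorine or a methoxy group in place of the methyl on this ring would give a number closer to that of compound 1 or to that of compound 3. On these data alone, it is also open whether the methyl step would keep its direction and size with chlorine in place of the bromine, or with no halogen on the ring at all.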